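The source may report more compounds than this note shows. Statements on the series, on what has been measured and on what is new or still open speak of the compounds shown alone.

In an assay on THP-1 cells for displacement of a labelled ligand from C-C chemokine receptor type 1 (Homo sapiens) (a lower number here means a stronger inhibitor, a higher number a weaker inhibitor), compound 3 `CC[C@@H](NC(=O)c1ccccc1)C(=O)N1CCC(c2ccc(Cl)cc2)CC1` gives 121 nM, level with compound 1 `O=C(N[C@@H](C(=O)N1CCC(c2ccc(Cl)cc2)CC1)C1CCCCC1)c1ccccc1`, which gives 121 nM; together they are the highest of the three numbers. Compound 2 `CC(C)[C@@H](NC(=O)CC1CC1)C(=O)N1CCC(c2ccc(Cl)cc2)CC1` gives 46 nM, the lowest of the three, but it differs from compound 3 in two places, so its value shows only where it stands, not what either change alone does. For the measured compounds named here, the only single-site step, no change at the digits printed from compound 1 to compound 3 (within the scatter), concerns the saturated chain carbon, not the carbonyl side. Compound 4 `CC[C@@H](NC(=O)CCc1ccccc1)C(=O)N1CCC(c2ccc(Cl)cc2)CC1` differs from compound 3 by phenethyl in place of phenyl on a carbonyl carbon. Going by the values given here, no measured step bears on this change, so compound 4 is expected to show a 1.5-fold lower number from compound 3 to compound 4 (0.18 log units; within the scatter), a shift not clearly beyond the scatter. For compound 4 the estimate is 80 nM, with a range from 25 nM to 250 nM.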

Compound 4, half-maximal inhibitory concentration: 85 nM
Compound 4: middle estimate off by 1.1-fold (0.03 log units), on the low side; low and high end bracket the measured number.
By their numbers in this assay, from the lowest: compounds 2, 4, 1 and 3 (each within the scatter of the next, the first and the last beyond it).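

The step at the carbonyl carbon whose other neighbour is the amide-type nitrogen, phenethyl in place of phenyl, gives a 1.4-fold lower number from compound 3 to compound 4 (0.15 log units; within the scatter) in this assay. For the compounds shown here, earlier, the only single-site step lay on the saturated chain carbon, so this is the first reading at this position, and the longer phenethyl group does not move the number beyond the scatter. Nothing available explains this result.

On these data alone, whether a longer chain, or an amine or carboxylic acid on the phenethyl ring, would shift the number beyond the scatter stays open. So does whether this step holds with cyclohexyl on the saturated chain carbon.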